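Fluoro in place of sulfamoyl: a toxicity forecast

This account rests on a few compounds, and the source may have more. Where it says the series, first, only, none or still open, it means among the compounds named here.

Two measured compounds set the scene: compound 1 (`CC(C)Oc1ccc(C(=O)Nc2ccc(N(C)C)cc2)cc1NC(=O)C(C)Br`) and compound 2 (`CN1CCN(Cc2ccc(NC(=O)c3ccc(OCCCCl)c(S(N)(=O)=O)c3)cc2C(F)(F)F)CC1`). In a toxicity assay on Huh-7.5 cells (Homo sapiens) for inhibition, read by MTT assay, with a stated time of 96 h (on this read-out higher numbers stand for lower toxicity in this test and lower numbers for higher toxicity in this test), compound 1 gives 7900 nM and compound 2 gives 5470 nM. These two values lie within the usual scatter of repeated measurements, so they cannot be told apart, and neither compound can be called the more toxic.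

The next compound, compound 3 (`CN1CCN(Cc2ccc(NC(=O)c3ccc(OCCCCl)c(F)c3)cc2C(F)(F)F)CC1`), keeps the rest of compound 2 but carries fluoro in place of sulfamoyl on an aromatic carbon, ortho to a 3-chloropropoxy group: fluoro in place of sulfamoyl on an aromatic carbon. Among the measured compounds shown here, no measured pair shows a change of this kind, so this assay offers no direct guide to its size or direction. The only hint is that two quite different structures, compound 1 at 7900 nM and compound 2 at 5470 nM, give values within the scatter of each other. The expected change, a 1.1-fold lower number from compound 2 to compound 3 (0.04 log units; within the scatter), is therefore estimated to stay within the scatter, with no firm direction. For compound 3 the estimated value is 5000 nM, with an expected range from 2200 nM to 12000 nM.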

Compound 3, half-maximal cytotoxic concentration: 8800 nM
Compound 3: middle estimate off by 1.8-fold (0.25 log units), on the low side; measured number inside the range.
By their numbers in this assay, from the lowest: compounds 2, 1 and 3 (each within the scatter of the next).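

Among the compounds shown here, this is the first direct look at this position: in this assay, putting fluoro in place of sulfamoyl on the aromatic carbon ortho to the 3-chloropropoxy group gives a 1.6-fold higher number from compound 2 to compound 3 (0.21 log units; within the scatter). The group that leaves has 4 heavy atoms, with 1 hydrogen-bond donor and 2 hydrogen-bond acceptors, while the group that enters has 1 heavy atom and neither donors nor acceptors, yet this test cannot tell the two compounds apart. For this one pair, then, sulfamoyl is not needed at this position to keep the reading where it stands, and no measurement at hand explains why the reading holds across so large a change in the group.

The compounds shown leave open whether an amine or a carboxylic acid on the same aromatic carbon would also stay within the scatter of compound 2 or would move the number clearly beyond it. They also leave open whether this swap would behave the same way with a longer chain in place of the 3-chloropropoxy group, since both compounds of the pair carry that group.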